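The compounds below may be only part of what the source reports. "The series", "measured", "known", "first", "only" and "open" are said of these compounds alone.

Of the compounds shown here, two have been measured so far in an ADME assay on THP-1 cells (Homo sapiens) for cytotoxicity, read by flow cytometry and propidium iodide staining, with a stated time of 72 h; a lower number here means a stronger inhibitor, a higher number a weaker inhibitor. There compound 1 `Cc1nc(CS(=O)(=O)c2ccc(Cl)cc2)c([N+](=O)[O-])n1CCO` gives 578000 nM and compound 2 `Cc1nc(CS(=O)(=O)c2ccccc2)c([N+](=O)[O-])n1CC(C)O` gives 418000 nM as its read-out, and these two numbers lie within the usual scatter of each other. Compound 2 therefore stands level with compound 1 on the evidence available.

Compound 3 `Cc1nc(CS(=O)(=O)c2ccc(Cl)cc2)c([N+](=O)[O-])n1CC(C)O` comes from compound 2 by a single change, chloro in place of hydrogen on an aromatic carbon para to a large group, which turns phenyl to 4-chlorophenyl. For the measured compounds named here, no measured pair in this small set isolates that change, and its effect in this assay remains unshown.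

The expectation is therefore a step no larger than the scatter, in neither direction. Compound 1, itself a 4-chlorophenyl compound, stands at 578000 nM and so within the scatter of compound 2. The estimate implies an expected change a 1.1-fold higher number from compound 2 to compound 3 (0.06 log units; within the scatter) that remains within the scatter. In this assay compound 3 is estimated at 480000 nM with an expected range from 250000 nM to 900000 nM before any measurement.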

Compound 3, half-maximal inhibitory concentration: > 688000 nM
Compound 3 was reported as a limit; the forecaster's own chance of this, stated with the estimate: 10%; middle value at least 1.4-fold (0.15 log units) from the limit.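

Compound 3 gives no number in this assay, only a limit: the limit of > 688000 nM in this assay, at which 1 of the 3 values shown sits.

Chloro in place of hydrogen on an aromatic carbon, para to a large group, now has a first reading in this assay, an at least 1.6-fold higher number from compound 2 to compound 3 (0.21 log units; that floor lies within the scatter), and this shows that the change brought no drop in the number at this position, although its true size stays unsettled. The second pair, with methyl in place of hydrogen on a saturated chain carbon, gives an at least 1.1-fold higher number from compound 1 to compound 3 (0.07 log units; that floor lies within the scatter), again only a floor, so neither change is shown to move the read-out beyond the scatter, and neither is shown to leave it within the scatter.

As far as these compounds go, how far the true value of compound 3 lies past its limit remains open, and with it whether either step truly exceeds the scatter. Also open, from the compounds shown here alone, is how fluoro or methoxy would read in place of chloro at the same ring position, and how an amine would read in place of the hydroxyl on the chain.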